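Cytotoxicity at one concentration: step from compound 1 to compound 4

A few compounds are considered here, and "the series" means these few. Any claim that something is new, unique, unknown or untested is made for them only; others in the source may bear on it.

All three measured compounds were run in an ADME assay on PC-3 cells (Homo sapiens) for cytotoxicity, read by WST assay, tested at 100 uM; on this read-out higher numbers stand for more inhibition at the one concentration tested (going by the name of the read-out) and lower numbers for less inhibition.

compound 1 `O=C(Nc1ccc(Cl)cc1)C1CCCN(C(=O)c2cccc([N+](=O)[O-])c2)C1`: 0%
compound 2 `CCc1cccc(NC(=O)C2CCCN(C(=O)c3cc(C(F)(F)F)cc(C(F)(F)F)c3)C2)c1`: 0%
compound 3 `COC(=O)c1cccc(NC(=O)C2CCCN(C(=O)c3cc(C(F)(F)F)cc(C(F)(F)F)c3)C2)c1`: 0%

Compound 1 stands level with compounds 2 and 3 at the digits given; no gap among the three reaches beyond the scatter. Within the data shown here, the only measured step, no change at the digits printed from compound 2 to compound 3 (within the scatter), changes a different group and does not bear directly on the change at hand. Compound 4 `CCN(CC)S(=O)(=O)c1cccc(C(=O)N2CCCC(C(=O)Nc3ccc(Cl)cc3)C2)c1` differs from compound 1 by diethylsulfamoyl in place of nitro on an aromatic carbon. Nothing measured speaks for a rise, and all three measured compounds sit at the floor of the read-out, so compound 4 is expected to sit there too, with an expected step of no change at the digits printed from compound 1 to compound 4 (within the scatter). Compound 4 is estimated at 0%, within 0% to 15%.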

Compound 4, a percentage reported as inhibition, at one concentration (the size of the read-out at that concentration, not a potency): 0%
For compound 4 middle estimate and measured number coincide at the digits printed; the range from low to high includes it.
By their numbers in this assay, from the lowest: compounds 1, 2, 3 and 4 (each within the scatter of the next).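

On the aromatic carbon meta to a large group, diethylsulfamoyl in place of nitro gives, in this assay, no change at the digits printed from compound 1 to compound 4 (within the scatter), so a much larger group at this position leaves the read-out at its floor. With compound 1 already at that floor, this step can show only the absence of a rise, not a fall. No available evidence bears on this result. From the compounds shown here alone, whether an amine or a carboxylic acid at this position would lift the read-out remains open. Also open, going by these compounds, is whether any change elsewhere on the shared core would register in this assay at all.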